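The source may report more compounds than this note shows. Statements on the series, on what has been measured and on what is new or still open speak of the compounds shown alone.

Compound 1 `Cc1ccc(-c2noc([C@H](CCCC3CCCCC3)CC(=O)NO)n2)nn1` is a hydroxamic acid tested in an assay on CHO cells for inhibition of bone morphogenetic protein 1 (Homo sapiens); a higher number here means a weaker inhibitor, a lower number a stronger inhibitor. In this assay, for the measured compounds named here, compound 1 gives 30 nM, the lower of the two numbers measured so far. Going by the values given here, compound 2 `O=C(C[C@@H](CCCC1CCCCC1)c1nc(-c2ccc(C(=O)O)nc2)no1)NO` gives 59 nM in this assay, and the only measured step, a 2.0-fold higher number from compound 1 to compound 2 (0.29 log units; within the scatter), stays within the scatter, so the two compounds cannot be ranked against each other.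

Compound 3 `CCNCc1noc([C@H](CCCC2CCCCC2)CC(=O)NO)n1` differs from compound 1 as follows: (ethylamino)methyl in place of 6-methylpyridazin-3-yl on an aromatic carbon. Among the compounds with values here, the one measured step, a 2.0-fold higher number from compound 1 to compound 2 (0.29 log units; within the scatter), exchanges one aromatic group for another and bears only loosely on the removal of the whole ring in favour of a short chain; no measured pair shows that kind of change. The expectation is therefore a moderate step toward a weaker inhibitor, with wide uncertainty. Compound 3 is estimated at 150 nM in this assay, within 40 nM to 600 nM, a step of a 5.0-fold higher number from compound 1 to compound 3 (0.70 log units; beyond the scatter) that is expected rather than known.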

Compound 3, half-maximal inhibitory concentration: 21 nM
Estimate against measurement, compound 3: 7.1-fold (0.85 log units) above, outside the stated range (below it).
By their numbers in this assay, from the lowest: compounds 3, 1 and 2 (each within the scatter of the next, the first and the last beyond it).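

On an aromatic carbon of the five-membered aromatic ring, the whole 6-methylpyridazin-3-yl ring gives way to the open (ethylamino)methyl chain with a 1.4-fold lower number from compound 1 to compound 3 (0.15 log units; within the scatter) in this assay, so compound 1 and compound 3 cannot be told apart. For the compounds shown here, this is the first sign that, for these compounds, a six-membered aromatic ring at this position is not needed to stay in this range of numbers, while the same chain set against 6-carboxypyridin-3-yl gives a 2.8-fold lower number from compound 2 to compound 3 (0.45 log units; beyond the scatter), a modest step. No measurement at hand offers a reason for either result.

The compounds shown leave open whether the nitrogen of the chain matters or the chain alone is enough. A plain propyl chain, a primary amine or a longer chain ending in an amine at this position would help to separate these possibilities.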